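Swapping an aryl for a phenylethyl group on a ring nitrogen

The compounds below may be only part of what the source reports. "The series", "measured", "known", "first", "only" and "open" are said of these compounds alone.

Of the compounds shown here, three that share a common core have been measured in an assay on CHO cells for displacement of a labelled ligand from adenosine receptor A2b (Homo sapiens), read by scintillation counting, with a stated time of 75 min, in the presence of a further agent that is not named here; a lower number here means a stronger inhibitor, a higher number a weaker inhibitor. Compound 1 `CCCn1c(=O)c2[nH]c(-c3ccc(S(=O)(=O)N4CCN(c5ccc(Cl)cc5)CC4)cc3)nc2n(CC)c1=O` gives 4.31 nM. Compound 2 `CCCn1c(=O)[nH]c2nc(-c3ccc(S(=O)(=O)N4CCN(c5ccc(Br)cc5)CC4)cc3)[nH]c2c1=O` gives 0.0835 nM. Compound 3 `CCCn1c(=O)[nH]c2nc(-c3ccc(S(=O)(=O)N4CCN(c5ccccc5)C(C)C4)cc3)[nH]c2c1=O` gives 7.15 nM. Compound 2 therefore has the lowest number of the three, and its distance to compound 1 and to compound 3 is in each case beyond the scatter of repeated measurements, so it is the strongest inhibitor of this small set.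

The next compound, compound 4 `CCCn1c(=O)[nH]c2nc(-c3ccc(S(=O)(=O)N4CCN(C(C)c5ccccc5)CC4)cc3)[nH]c2c1=O`, has not yet been measured in this assay. It differs from compound 2 in a single place: 1-phenylethyl in place of 4-bromophenyl on an amine nitrogen in a ring. The 4-bromophenyl is thus replaced by a 1-phenylethyl group on the same ring nitrogen.

Going by the values given here, no directly comparable pair has been measured for such a change. Both compound 1 and compound 3 keep an aromatic ring on that nitrogen and already sit well above compound 2, which suggests that departing from the 4-bromophenyl arrangement of compound 2 costs affinity. The step from compound 2 to compound 4 is expected to be a 30-fold higher number from compound 2 to compound 4 (1.48 log units; beyond the scatter), a clear rise in the number beyond the scatter. Compound 4 is estimated at 2.5 nM, with a plausible range from 0.3 nM to 20 nM.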

Compound 4, inhibition constant: 8.34 nM
The estimate for compound 4 lay 3.3-fold (0.52 log units) below the measured number, within the range that was stated.
By their numbers in this assay, from the lowest: compound 2; then compounds 1, 3 and 4 (each within the scatter of the next).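

In this assay, going by these compounds alone, this is the first comparison that changes only the group on this ring nitrogen, and it gives a 100-fold higher number from compound 2 to compound 4 (2.00 log units; beyond the scatter), a large step that shows affinity depends strongly on what this position carries. Both groups have one six-membered aromatic ring of carbon only, no hydrogen-bond donors or acceptors and no net charge, so a matching ring and matching counts are not enough to keep the low number of compound 2. The swap also changes two things at once: the bromine leaves, and the aromatic ring no longer sits directly on the nitrogen but is attached through a branched carbon, and no measurement here accounts for the rise or assigns it to either change.

From the compounds shown here alone, the share of each change remains open: a 1-(4-bromophenyl)ethyl group on this nitrogen would keep the bromine while retaining the branched link, directly testing whether the bromine matters in the new arrangement. A plain benzyl group would likewise show what the methyl branch of 1-phenylethyl contributes to the step.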